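The source may report more compounds than this note shows. Statements on the series, on what has been measured and on what is new or still open speak of the compounds shown alone.

Compound 1 `O=C(N/N=C/c1ccccc1)c1cnccn1` stands highest of the two numbers recorded in an ADME assay on J774 cells (Mus musculus) for cytotoxicity, read by MTT assay, with a stated time of 48 h, tested at 150 ug/mL (a higher number here means a weaker effect of the compound at the concentration tested, a lower number a stronger effect), where compound 1 gives 100%. Its nearest neighbour is compound 2 `O=C(N/N=C/c1cccc(F)c1)c1cnccn1`, which gives 40% in this assay, a shift described by a number 60 percentage points lower from compound 1 to compound 2 (beyond the scatter). Compound 3 `COc1ccc(/C=N/NC(=O)c2cnccn2)cc1` differs from compound 1 by methoxy in place of hydrogen on an aromatic carbon. Going by the values given here, the only measured step bearing on this change is the fluoro substitution, which was large, so a drop of a similar sign but uncertain size is expected for compound 3. Compound 3 is estimated at 65% in this assay, within 35% to 100%, a step of a number 35 percentage points lower from compound 1 to compound 3 (beyond the scatter).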

Compound 3, a percentage reported as activity, at one concentration (the size of the read-out at that concentration, not a potency): 55%
Compound 3: middle estimate off by 10 percentage points, on the high side; low and high end bracket the measured number.
By their numbers in this assay, from the lowest: compound 2; then compound 3; then compound 1.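

In this assay, methoxy in place of hydrogen, para to a large group, gives a number 45 percentage points lower from compound 1 to compound 3 (beyond the scatter). Going by these compounds alone, this shows that a change at this place on the carbon-only aromatic ring can also lower the number, and that the large step seen with fluoro, a number 60 percentage points lower from compound 1 to compound 2 (beyond the scatter), is not the only one from compound 1. Nothing available explains the step.

On these data alone, whether an amine, a carboxylic acid or a longer chain such as butoxy at this place would also lower the number stays open. So does the effect of methoxy elsewhere on this ring.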